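The source may report more compounds than this note shows. Statements on the series, on what has been measured and on what is new or still open speak of the compounds shown alone.

Compound 1 `Cc1cc(NC(=O)Nc2ccc(C)c(Cl)c2)c2ccccc2n1`: > 25000 nM
Compound 2 `COc1ccc(NC(=O)Nc2cc(C)nc3ccccc23)cc1OC`: > 25000 nM

Both readings come from an ADME assay on HEK293 cells (Homo sapiens) for cytotoxicity, with a stated time of 72 h; a lower number here means that less compound is needed, a higher number that more compound is needed for the effect. Neither compound gives a number, only (the limit of > 25000 nM in this assay, at which 2 of the 2 values shown sit). Going by the values given here, compound 2 therefore has a limit of the assay as its only reading, not an exact value.

Compound 3 `COc1ccc(NC(=O)Nc2cc(C)nc3ccccc23)cc1F` keeps the rest of compound 2 and changes one group: fluoro in place of methoxy on an aromatic carbon. This places fluoro in place of methoxy on an aromatic carbon, ortho to a methoxy group and meta to a large group.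

Among the compounds with values here, no measured pair shows what a single change does, so any forecast is uncertain. The expectation starts from compound 2, whose limit is > 25000 nM. No step beyond the scatter is expected, and neither direction is favoured. The expected change is a number no higher from compound 2 to compound 3 (the limit leaves the size open). For compound 3 the estimated value is 25000 nM, with an expected range of 12000 nM to 50000 nM.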

Compound 3, half-maximal effective concentration: > 25000 nM
Compound 3: a limit, no number; the forecaster's own chance of this, stated with the estimate: 80%; the middle value sits exactly at the limit.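

Compound 2 and compound 3 both give a limit rather than a number, so no step can be read for fluoro in place of methoxy: the limit of > 25000 nM in this assay, at which 3 of the 3 values shown sit. The compounds shown leave open whether any change in this series would give a measurable value.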